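The source may hold more compounds than are shown below. What is called first, only, known or untested is meant among the compounds shown, and "the series" means these compounds.

Working notes on the series, read in an ADME assay on HFF cells (Homo sapiens) for cytotoxicity, with a stated time of 8 days; on this read-out lower numbers stand for higher toxicity in this test and higher numbers for lower toxicity in this test. Compound 1 (`Nc1nc(NC2CC2)c2ncn(/C=C3/CC3(CO)CO)c2n1`) gives > 300000 nM, which is a limit and not a number. Compound 2 (`Nc1nc(NC2CCCC2)c2ncn(/C=C3/CC3(CO)CO)c2n1`) gives > 300000 nM, again a limit. Compound 3 (`CCCCCCCCSc1nc(N)nc2c1ncn2/C=C1/CC1(CO)CO`) gives > 300000 nM, also a limit, so compound 3 has no exact place on the scale. All measured members share one read-out: the limit of > 300000 nM in this assay, at which 3 of the 3 values shown sit.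

The next member is compound 4 (`CCCCCOc1nc(N)nc2c1ncn2/C=C1/CC1(CO)CO`), where pentyloxy takes the place of octylsulfanyl on an aromatic carbon: pentyloxy in place of octylsulfanyl on an aromatic carbon.

The closest measured precedents change the group at that same aromatic carbon: a step that the two limits leave unreadable from compound 1 to compound 3 and a step that the two limits leave unreadable from compound 2 to compound 3. The remaining comparison is a step that the two limits leave unreadable from compound 1 to compound 2, a change from cyclopropyl to cyclopentyl on a nitrogen. None of the three gives a size, and none shows a direction.

No step beyond the scatter is expected in this assay because the limit of > 300000 nM in this assay, at which 3 of the 3 values shown sit, and the aminated and octylsulfanyl members do not separate on it. The expected change is a number no higher from compound 3 to compound 4 (the limit leaves the size open), most likely with a further limit as the result. The estimate for compound 4 is 300000 nM, with an expected range of 150000 nM to 400000 nM.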

Compound 4, half-maximal cytotoxic concentration: 259000 nM
Compound 4: middle estimate off by 1.2-fold (0.06 log units), on the high side, within the range that was stated.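

The steps among compound 1, compound 2 and compound 3 cannot be read, whereas in this assay compound 4 gives 259000 nM, an exact number for a group at this aromatic carbon. Set against the other three members, pentyloxy gives an at least 1.1-fold lower number from compound 3 to compound 4 (0.06 log units; that floor lies within the scatter), an at least 1.1-fold lower number from compound 2 to compound 4 (0.06 log units; that floor lies within the scatter) and an at least 1.1-fold lower number from compound 1 to compound 4 (0.06 log units; that floor lies within the scatter). Each of these is a floor that is open on its upper side, so pentyloxy is not shown to separate from octylsulfanyl, cyclopentylamino or cyclopropylamino, and a single limit still governs the read-out of the series: the limit of > 300000 nM in this assay, at which 3 of the 4 values shown sit.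

As far as these compounds go, the true size of all three steps stays open, as does whether any step belongs to the oxygen in place of sulfur or to the length of the chain; pentyloxy differs from octylsulfanyl in both. Octyloxy or pentylsulfanyl at the same aromatic carbon would change only one of these two features at a time, and a shorter chain such as methoxy would show whether the exact number holds across the ethers.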